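The source may report more compounds than this note shows. Statements on the series, on what has been measured and on what is new or still open speak of the compounds shown alone.

In a functional assay on the whole organism (strain Wistar albino) for inhibition, with Rattus norvegicus as the target, read by paw edema, with stated times of 1 h and 3 h, at a dose of 0.32 mmol/kg by the intraperitoneal route (a lower number here means less inhibition, a higher number more inhibition at the dose given (going by the name of the read-out)), the measured compounds are:

Compound 1, `Cc1ccc(-c2nn(-c3ccc(Cl)cc3)cc2/C=N\c2ccccc2)cc1`, giving 49.3%.
Compound 2, `Cc1ccc(-c2nn(-c3ccc(Cl)cc3)cc2/C=N\c2ccc(Cl)cc2)cc1`, giving 49.2%.
Compound 3, `COc1ccc(-c2nn(-c3ccc(Cl)cc3)cc2/C=N\c2ccc(Cl)cc2)cc1`, giving 72.6%.

Compound 2 holds the lowest of the three numbers, but its nearest neighbour is compound 1, and the step of a number 0.1 percentage points lower from compound 1 to compound 2 (within the scatter) lies within the scatter, so no order can be drawn between those two. Compound 3 stands furthest from compound 2, the step of a number 23.4 percentage points higher from compound 2 to compound 3 (beyond the scatter) being the only one beyond the scatter.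

Compound 4, `Cc1ccc(-c2nn(-c3ccc(S(N)(=O)=O)cc3)cc2/C=N\c2ccc(Cl)cc2)cc1`, differs from compound 2 in one place: sulfamoyl in place of chloro on an aromatic carbon. Going by the values given here, no measured step bears on this change. The step of a number 0.1 percentage points lower from compound 1 to compound 2 (within the scatter) concerns chloro entering on a different aromatic carbon, and the step of a number 23.4 percentage points higher from compound 2 to compound 3 (beyond the scatter) concerns methoxy in place of methyl; neither involves a sulfamoyl group, so the data offer no guide to its effect. Starting from compound 2 alone, the step of a number 0.8 percentage points higher from compound 2 to compound 4 (within the scatter) is therefore expected to lie within the scatter. Compound 4 is estimated at 50%, with a wide range from 32% to 70%.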

Compound 4, a percentage reported as inhibition, in the whole organism at one dose (the size of the read-out at that dose, not a potency): 78.4%
Estimate against measurement, compound 4: 28.4 percentage points below; the whole stated range lies below it.
By their numbers in this assay, from the lowest: compounds 2 and 1 (each within the scatter of the next); then compounds 3 and 4 (each within the scatter of the next).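

In this assay, going by these compounds alone, the step of a number 29.2 percentage points higher from compound 2 to compound 4 (beyond the scatter) shows that this aromatic carbon, para to a large group, responds to what it carries, which the earlier compounds could not show since all of them hold chloro there. Within the data shown here, it is also the first change on this ring, and 4-sulfamoylphenyl in place of 4-chlorophenyl gives a step of about the same modest size as the one seen on the other ring with methoxy in place of methyl. No measurement shown here explains why the number rises with sulfamoyl on this carbon.

Still open, as far as these compounds go, is whether the rise is particular to sulfamoyl or would also come with a carboxylic acid or an amine on the same carbon. Also open, from the compounds shown here alone, is whether sulfamoyl and methoxy together in one compound would add to each other.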